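A Single Group Swap on Compound 2

The source may hold more compounds than are shown below. What is called first, only, known or untested is meant among the compounds shown, and "the series" means these compounds.

Among the compounds with values here, in an ADME assay on L02 cells (Homo sapiens) for inhibition, read by CCK-8 assay, with a stated time of 48 h (on this read-out higher numbers stand for weaker inhibition of growth and lower numbers for stronger inhibition of growth), only two compounds have been tested so far. Compound 1 `Cc1ccccc1Nc1nc(NC2CCCCC2)ncc1Cl` gives > 100000 nM as its result, which is a limit of the assay and not a number. Within the data shown here, compound 2 `CN1CCN(c2ccc(Nc3ncc(Cl)c(NCc4ccc(F)cc4)n3)nc2)CC1` gives 39700 nM and so holds the only true number available.

Compound 3 `CC(C)c1ccc(Nc2nc(Nc3ccc(N4CCN(C)CC4)cn3)ncc2Cl)cc1` has not yet been measured. It matches compound 2 except for one change: 4-isopropylphenyl in place of 4-fluorobenzyl on a nitrogen on an aromatic ring while the rest of the molecule stays the same.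

Among the measured compounds shown here, no two tested compounds differ in just one place, so the data offer no direct guide to the size of this change. The natural starting point is therefore compound 2 at 39700 nM in this assay as the reference. A small shift toward stronger inhibition of growth is expected, one that stays within the usual scatter, with an estimated step of a 1.6-fold lower number from compound 2 to compound 3 (0.20 log units; within the scatter) in this direction. For compound 3 the expected value is 25000 nM with an estimated range from 8000 nM to 80000 nM in this assay.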

Compound 3, concentration for 50% growth inhibition: 13700 nM
The estimate for compound 3 lay 1.8-fold (0.26 log units) above the measured number, and the stated range covers the measured number.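

Within the data shown here, this is the first comparison in this assay between compounds that differ in one place, and the swap of 4-fluorobenzyl for 4-isopropylphenyl on this nitrogen gives a 2.9-fold lower number from compound 2 to compound 3 (0.46 log units; beyond the scatter). Among these compounds, the step is modest but lies beyond the usual scatter, so the group at this place does affect the read-out, which could not be seen from the earlier compounds alone. Compound 1 remains the only compound resting on a limit of the assay and not a number, so this step is read between two true numbers: the limit of > 100000 nM in this assay, at which 1 of the 3 values shown sits.

The change alters two things at once, since the carbon link of the benzyl group goes and isopropyl takes the place of fluorine, and the compounds shown cannot separate these two parts; a 4-fluorophenyl or a 4-isopropylbenzyl group on the same nitrogen would pull them apart. Also open, as far as these compounds go, is how this place would respond to a group carrying an amine or a carboxylic acid, and why the number moved at all.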